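The source may report more compounds than this note shows. Statements on the series, on what has been measured and on what is new or still open speak of the compounds shown alone.

Three compounds share one core and differ only in the group on the amide-type nitrogen. Compound 1 `CCCCCCCCCCCCn1nnc(C(C(=O)Nc2ccc(F)cc2F)c2ccccc2)n1` gives 1% in an assay on isolated protein for inhibition of sterol O-acyltransferase 1 (Mus musculus), tested at 0.1 uM (on this read-out lower numbers stand for less inhibition and higher numbers for more inhibition at the one concentration tested (going by the name of the read-out)), compound 2 `CCCCCCCCCCCCn1nnc(C(C(=O)Nc2ncccc2C)c2ccccc2)n1` gives 4%, and compound 3 `CCCCCCCCCCCCn1nnc(C(C(=O)Nc2ccc3c(C)cc(C)nc3n2)c2ccccc2)n1` gives 49%, the highest of the three. Putting the group of 2 six-membered aromatic rings in place of one six-membered aromatic ring at this position raised the read-out sharply: a number 48 percentage points higher from compound 1 to compound 3 (beyond the scatter) and a number 45 percentage points higher from compound 2 to compound 3 (beyond the scatter), whereas a number 3 percentage points higher from compound 1 to compound 2 (within the scatter). Compound 4 `CCCCCCCCCCCCn1nnc(C(C(=O)NC(C)(C)C)c2ccccc2)n1` alters this same position once more: a group of 4 heavy atoms (4 carbon; no ring) in place of a group of 12 heavy atoms (10 carbon, 2 nitrogen; 2 six-membered aromatic rings with 1 hetero atom each), on an amide-type nitrogen. Both large steps appeared when that two-ring group entered; here it leaves for a group with no ring, so a large fall is expected, a number 41 percentage points lower from compound 3 to compound 4 (beyond the scatter). Compound 4 is therefore estimated at 8%, most likely between 0% and 30%.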

Compound 4, a percentage reported as inhibition, at one concentration (the size of the read-out at that concentration, not a potency): 1%
Beside the measured number, compound 4's estimate is 7 percentage points above it; the range from low to high includes it.
By their numbers in this assay, from the lowest: compounds 1, 4 and 2 (each within the scatter of the next); then compound 3.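

In this assay the two-ring group remains the only group shown that raises the number: tert-butyl in its place gives a number 48 percentage points lower from compound 3 to compound 4 (beyond the scatter). A group with no ring cannot be told apart from the single-ring groups, with a number 3 percentage points lower from compound 2 to compound 4 (within the scatter) and no change at the digits printed from compound 1 to compound 4 (within the scatter), so an aromatic ring on this amide-type nitrogen is not enough by itself. Nothing available explains why the two-ring group stands apart. As far as these compounds go, whether a naphthyl group, with carbon only in both rings, would match it stays open, as does the effect of a carboxylic acid or a longer chain on this nitrogen.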